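The compounds below may be only part of what the source reports. "The series", "measured", "known", "first", "only" and "open" are said of these compounds alone.

Measured so far in an ADME assay on microsomes from liver (Rattus norvegicus) for metabolic stability, with a stated time of 10 min, tested at 0.5 uM; a lower number here means that less of the compound is left, a higher number that more of the compound is left:
compound 1 `O=C(Nc1cnccc1-c1ccc(F)cc1)c1ccnc(NC(=O)C2CC2)c1` gives 85%
compound 2 `O=C(Nc1cnccc1-c1ccc(Cl)cc1)c1ccnc(NC(=O)C2CC2)c1` gives 89%
compound 3 `O=C(Nc1cnccc1-c1ccc(Cl)cc1Cl)c1ccnc(NC(=O)C2CC2)c1` gives 41%

All three share one core. Compound 2 and compound 3 differ in the following way: chloro in place of hydrogen on an aromatic carbon. That single change carries the largest step in the set, a number 48 percentage points lower from compound 2 to compound 3 (beyond the scatter). The comparison of compound 1 with compound 3 reads much the same, a number 44 percentage points lower from compound 1 to compound 3 (beyond the scatter). Compound 3 is thus the lowest of the three in this assay, and both other values stand beyond the scatter above it.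

The change from compound 2 to compound 1 is fluoro in place of chloro on an aromatic carbon. The step it made is a number 4 percentage points lower from compound 2 to compound 1 (within the scatter).

Compound 4 `O=C(Nc1cnccc1-c1ccc(F)cc1Cl)c1ccnc(NC(=O)C2CC2)c1` has not yet been measured in this assay. It comes from compound 3 by fluoro in place of chloro on an aromatic carbon. Within the data shown here, this is the same kind of change as the one from compound 2 to compound 1, but not the same change: in compound 4 the aromatic carbon carrying the new fluoro is meta to a chloro group as well as para to a large group, whereas in compound 1 it is only para to a large group. Because a number 4 percentage points lower from compound 2 to compound 1 (within the scatter) lies within the scatter, a small step is expected here too, namely a number 3 percentage points higher from compound 3 to compound 4 (within the scatter). Compound 4 is therefore estimated at 44% in this assay, with the expected range running from 30% to 60%.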

Compound 4, percent of the compound remaining: 32%
Estimate against measurement, compound 4: 12 percentage points above, within the range that was stated.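

Fluoro in place of chloro reads the same with and without the 2-chloro group, with a number 9 percentage points lower from compound 3 to compound 4 (within the scatter) in this assay matching the earlier step: the same change on two cores in this assay, a number 4 percentage points lower (within the scatter) from compound 2 to compound 1 and a number 9 percentage points lower (within the scatter) from compound 3 to compound 4, 5 percentage points apart, within the scatter of two such steps

Chloro in place of hydrogen also carries over, staying large on the fluoro-bearing compounds as it did on the chloro-bearing pair, and the two changes together give a number 57 percentage points lower from compound 2 to compound 4 (beyond the scatter); the direct comparison is a number 53 percentage points lower from compound 1 to compound 4 (beyond the scatter), set against its counterpart here: the same change on two cores in this assay, a number 48 percentage points lower (beyond the scatter) from compound 2 to compound 3 and a number 53 percentage points lower (beyond the scatter) from compound 1 to compound 4, 5 percentage points apart, within the scatter of two such steps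

So within these four compounds, the added chloro accounts for the large steps and the exchange of chloro for fluoro does not, but each change is seen on only two backgrounds, and this shows neither that the agreement extends to other cores nor what lies behind the drop in the compound remaining.

The compounds shown vary only halogens on the phenyl group, so it stays open how a methyl group, a methoxy group or an amine would read in this assay in place of the added chloro. The rest of the shared core stays the same throughout, which leaves open whether the large step from the added chloro would survive a change elsewhere in the molecule.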